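The source may hold more compounds than are shown below. What is called first, only, known or untested is meant among the compounds shown, and "the series" means these compounds.

The measured compounds:

Compound 1, `C=C1C[C@]23C[C@@]1(O)CC[C@H]2c1ccc(OS(=O)(=O)c2ccc(C)cc2)c(C)c1[C@@H]3Cn1cc(-c2ccc(C)cc2)nn1`. In a functional assay on MCF7 cells (Homo sapiens) for cytotoxicity, read by MTT assay, with a stated time of 4 days (on this read-out lower numbers stand for stronger inhibition and higher numbers for weaker inhibition), compound 1 reaches only the limit of the assay, > 20000 nM.
Compound 2, `C=C1C[C@]23C[C@@]1(O)CC[C@H]2c1ccc(O)c(C)c1[C@@H]3Cn1cc(-c2ccc(F)cc2)nn1`. In this assay compound 2 also reaches only the limit, > 20000 nM.
Compound 3, `C=C1C[C@]23C[C@@]1(O)CC[C@H]2c1ccc(O)c(C)c1[C@@H]3Cn1cc(-c2ccc(OC)cc2)nn1`. In this assay compound 3 likewise sits at the limit, > 20000 nM.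

All three share one core and none of them shows a readable number; every value shown is the same limit, (the limit of > 20000 nM in this assay, at which 3 of the 3 values shown sit). Compound 3 therefore stands nowhere in particular among the numbers: it sits where all of them sit. Among the measured compounds shown here, the one step between two measured compounds that differ in a single place, a step that the two limits leave unreadable from compound 2 to compound 3, cannot be sized, since both ends are limits.

Compound 4 is `C=C1C[C@]23C[C@@]1(O)CC[C@H]2c1ccc(O)c(C)c1[C@@H]3Cn1cc(-c2ccc(C)cc2)nn1`. It differs from compound 3 by methyl in place of methoxy on an aromatic carbon. For the measured compounds named here, no measured step tells how such a change shifts the read-out, and the only neighbouring step, a step that the two limits leave unreadable from compound 2 to compound 3, is unreadable. Since compound 3 gives only > 20000 nM, the most likely outcome is that compound 4 again reaches only the limit. Compound 4 is thus expected to give about 30000 nM, within a range of 8000 nM to 120000 nM. The expected step is a step that the limit leaves unreadable from compound 3 to compound 4, that is, none beyond the scatter.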

Compound 4, half-maximal inhibitory concentration: > 20000 nM
Compound 4 gave a limit, no number (the forecaster's own chance of this, stated with the estimate: 85%); the middle value does not contradict the limit.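

The steps from compound 1, compound 2 and compound 3 to compound 4 cannot be read, since each value is a limit and not a number: the limit of > 20000 nM in this assay, at which 4 of the 4 values shown sit.

The compounds shown leave open which change to the shared core, if any, would give a readable number in this assay.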